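Methoxy analogue of compound 1: expected growth inhibition

This account rests on a few compounds, and the source may have more. Where it says the series, first, only, none or still open, it means among the compounds named here.

Measured so far:
compound 1 `Cc1nc(SCC(=O)Nc2nc(-c3ccc(Cl)cc3)cs2)n(Nc2ccccc2)c1C` — 2950 nM
compound 2 `Cc1ccc(Nn2c(SCC(=O)Nc3nc(-c4ccccc4)cs3)nc(C)c2C)cc1` — 4130 nM

In a functional assay on KM12 cells (Homo sapiens) for antiproliferative activity, read by sulforhodamine B assay, with a stated time of 48 h (on this read-out higher numbers stand for weaker inhibition of growth and lower numbers for stronger inhibition of growth), compound 1 gives 2950 nM, the lower of the two numbers recorded. Compound 2, with 4130 nM, differs from compound 1 at two places at once, and its value lies within the usual scatter of that of compound 1, so no order between the two can be read. Among the measured compounds shown here, no pair of measured compounds differs in a single place, so no measured step is available as a guide.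

The unmeasured compound 3 `COc1ccc(Nn2c(SCC(=O)Nc3nc(-c4ccc(Cl)cc4)cs3)nc(C)c2C)cc1` derives from compound 1 by methoxy in place of hydrogen on an aromatic carbon. For the measured compounds named here, with no matching step to draw on, and the only other substituted analogue, compound 2, sitting within the scatter of compound 1, the expected step of a 1.2-fold higher number from compound 1 to compound 3 (0.07 log units; within the scatter) is none beyond the scatter. For compound 3 in this assay the estimate is 3500 nM, in a range from 1500 nM to 8000 nM.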

Compound 3, concentration for 50% growth inhibition: 1840 nM
Compound 3: middle estimate off by 1.9-fold (0.28 log units), on the high side, within the range that was stated.
By their numbers in this assay, from the lowest: compounds 3, 1 and 2 (each within the scatter of the next, the first and the last beyond it).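

Methoxy on an aromatic carbon of the six-membered ring of carbon only, para to a large group, gives the first single-place comparison in the series (a 1.6-fold lower number from compound 1 to compound 3 (0.21 log units; within the scatter)) in this assay. Growth inhibition in the low micromolar range is therefore kept with this group in place, and no difference can be read between compound 1 and compound 3. Nothing measured here offers an explanation for the size of this step.

Open, going by these compounds, is whether an amine, a carboxylic acid or a longer chain such as butoxy at this same place would give a step beyond the scatter. Also open, on these data alone, is whether methoxy behaves alike on the core of compound 2, which differs from compound 1 at two places at once and so gives no single-place reading.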